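The compounds below may be only part of what the source reports. "The series", "measured", "known", "first", "only" and "open" are said of these compounds alone.

In an ADME assay on BJ cells (Homo sapiens) for cytotoxicity, with a stated time of 72 h (a lower number here means that less compound is needed, a higher number that more compound is needed for the effect), compound 2 `C=C[C@@](C)(/C=C/c1ccc(Nc2c(F)cc(F)cc2F)cc1)CCC=C(C)C` gives > 36600 nM as a limit and not a number. Compound 1 `C=C[C@@](C)(/C=C/c1ccc(Nc2ccc(F)cc2)cc1)CCC=C(C)C` gives > 36600 nM as a limit too. Going by the values given here, the only measured step that bears on the change is a step that the two limits leave unreadable from compound 1 to compound 2 and it offers no size to carry over, with compound 1 and compound 2 both at the limit of > 36600 nM in this assay, at which 2 of the 2 values shown sit, in the measurements so far. Compound 3 `C=C[C@@](C)(/C=C/c1ccc(Nc2ccc(Cl)cc2)cc1)CCC=C(C)C` differs from compound 2 by 4-chlorophenyl in place of 2,4,6-trifluorophenyl on a nitrogen on an aromatic ring and nothing else. No step beyond the scatter is expected in this assay and no direction is favoured. The expected step is a number no higher from compound 2 to compound 3 (the limit leaves the size open) in this reading. For compound 3 the estimate is 36600 nM with an expected range of 18000 nM to 73000 nM in that assay.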

Compound 3, half-maximal effective concentration: > 36600 nM
Compound 3 was reported as a limit; the forecaster's own chance of this, stated with the estimate: 75%; the middle value sits exactly at the limit.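

In this assay no new step can be read among compound 1, compound 2 and compound 3, each of which stands at a limit and not a number: the limit of > 36600 nM in this assay, at which 3 of the 3 values shown sit. In this assay the compounds shown leave open whether 4-fluorophenyl, 2,4,6-trifluorophenyl and 4-chlorophenyl on the nitrogen differ at all.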